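The source may report more compounds than this note shows. Statements on the series, on what has been measured and on what is new or still open speak of the compounds shown alone.

Of the compounds shown here, three that share one core have been measured in a functional assay on HFF cells (Homo sapiens) for cytotoxicity; on this read-out higher numbers stand for lower toxicity in this test and lower numbers for higher toxicity in this test. Compound 1 `CCCCCOc1nc(N)nc2c1ncn2/C=C1/C[C@@H]1CO`, which carries pentyloxy, gives 41900 nM, the second highest of the three numbers. Compound 2 `COc1nc(N)nc2c1ncn2/C=C1/C[C@@H]1CO`, with methoxy in that place, gives 15800 nM, and compound 3 `C#CCNc1nc(N)nc2c1ncn2/C=C1/C[C@@H]1CO`, with propargylamino there, gives 306000 nM.

Compound 4 `C=CCOc1nc(N)nc2c1ncn2/C=C1/C[C@@H]1CO` has not been measured yet. It differs from compound 1 by vinyl in place of butyl on a saturated chain carbon bound to an oxygen on an aromatic ring, so that pentyloxy becomes allyloxy.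

The closest guide is a 2.7-fold lower number from compound 1 to compound 2 (0.42 log units; beyond the scatter), a modest step that also shortens the chain on the oxygen. The larger steps, a 7.3-fold higher number from compound 1 to compound 3 (0.86 log units; beyond the scatter) and a 19-fold higher number from compound 2 to compound 3 (1.29 log units; beyond the scatter), both bring in propargylamino, a swap that compound 4 does not make, so they say little here. Allyloxy is a shorter chain than pentyloxy but a longer one than methoxy, so only part of that modest step is expected, in the same downward direction. The expected change is a 1.7-fold lower number from compound 1 to compound 4 (0.22 log units; within the scatter), which is small. For compound 4 the estimated value is 25000 nM, with an expected range of 11000 nM to 60000 nM.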

Compound 4, half-maximal cytotoxic concentration: 220000 nM
Compound 4: the middle estimate sits 8.8-fold (0.94 log units) below what was measured; the whole stated range lies below it.
By their numbers in this assay, from the lowest: compound 2; then compound 1; then compounds 4 and 3 (each within the scatter of the next).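

In this assay, the numbers on this oxygen do not follow chain length: allyloxy is shorter than pentyloxy, yet the change gives a 5.3-fold higher number from compound 1 to compound 4 (0.72 log units; beyond the scatter) and not the drop that shortening to methoxy gave. Set against the shortest chain, allyloxy gives a 14-fold higher number from compound 2 to compound 4 (1.14 log units; beyond the scatter) in the same upward direction, so methoxy and pentyloxy both sit on the lower side of allyloxy. Replacing propargylamino with allyloxy on the aromatic carbon gives a 1.4-fold lower number from compound 3 to compound 4 (0.14 log units; within the scatter) and so stays within the scatter, which shows that an oxygen-linked chain can match the amino-linked one here.

No available evidence explains the jump from pentyloxy to allyloxy. A saturated propyl chain on the same oxygen would separate the effect of the double bond from that of chain length, and a propargyl chain there would test the triple bond.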